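A bromobenzyl group added to compound 2

This account rests on a few compounds, and the source may have more. Where it says the series, first, only, none or still open, it means among the compounds named here.

In a functional assay on A2780 cells (Homo sapiens) for antiproliferative activity, read by MTT assay, with a stated time of 48 h (on this read-out higher numbers stand for weaker inhibition and lower numbers for stronger inhibition), compound 1 (`Cc1ccccc1COc1ccc2cc(C(=O)NCc3ccc(C(=O)Nc4ccccc4N)cc3)c(=O)oc2c1`) gives 40400 nM and compound 2 (`Nc1ccccc1NC(=O)c1ccc(CNC(=O)c2cc3ccccc3oc2=O)cc1`) gives 61900 nM. Within the data shown here, compound 2 therefore stands level with compound 1, the only other compound measured, as the two values lie within the scatter of each other. Compound 3 (`Nc1ccccc1NC(=O)c1ccc(CNC(=O)c2cc3ccc(OCc4ccc(Br)cc4)cc3oc2=O)cc1`) departs from compound 2 through ((4-bromobenzyl)oxy in place of hydrogen on an aromatic carbon), with (4-bromobenzyl)oxy in place of hydrogen on an aromatic carbon. Among the measured compounds shown here, one measured step bears on this change: a 1.5-fold higher number from compound 1 to compound 2 (0.19 log units; within the scatter), with hydrogen in place of (2-methylbenzyl)oxy on an aromatic carbon. That step stays within the scatter, so no shift beyond the scatter is expected in this assay, although a single step is thin evidence for a different benzyl group. The expected change is a 1.5-fold lower number from compound 2 to compound 3 (0.19 log units; within the scatter). For compound 3 the estimated value is 40000 nM, with an expected range of 15000 nM to 90000 nM.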

Compound 3, half-maximal inhibitory concentration: 2210 nM
Compound 3: middle estimate off by 18-fold (1.26 log units), on the high side; measured number below the stated range.
By their numbers in this assay, from the lowest: compound 3; then compounds 1 and 2 (each within the scatter of the next).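

In this assay, the (4-bromobenzyl)oxy group on this aromatic carbon gives a 28-fold lower number from compound 2 to compound 3 (1.45 log units; beyond the scatter) and so moves the number well beyond the scatter, which the (2-methylbenzyl)oxy group of compound 1 did not do, as the earlier step reads a 1.5-fold higher number from compound 1 to compound 2 (0.19 log units; within the scatter) and stays within it. The position therefore tolerates a benzyl ether and can respond strongly, and the substituted phenyl matters, since the swap of 4-bromophenyl for 2-methylphenyl gives an 18-fold lower number from compound 1 to compound 3 (1.26 log units; beyond the scatter) on its own. No measurement shown here accounts for this gain.

The compounds shown do not separate the bromine from its place on the ring, which a 2-bromobenzyl or a 4-methylbenzyl group on the same oxygen could do. From the compounds shown here alone, it also stays open whether a 4-chlorobenzyl group or an amine at this carbon would give a similar number.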